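Amide variation on the trimethoxyphenyl chromene series

This account rests on a few compounds, and the source may have more. Where it says the series, first, only, none or still open, it means among the compounds named here.

Compound 3 `COc1ccc2c(c1)OC(c1cc(OC)c(OC)c(OC)c1)C(C(=O)Nc1ccccc1)=C2` gives 17500 nM in a functional assay for inhibition of nuclear factor NF-kappa-B complex (Homo sapiens) (on this read-out higher numbers stand for weaker inhibition and lower numbers for stronger inhibition), the lowest of the two numbers here, though its nearest neighbour compound 1 `CCOC(=O)C1=Cc2ccc(OC)cc2OC1c1cc(OC)c(OC)c(OC)c1` gives 25000 nM in this assay, a gap that lies inside the usual scatter. Compound 2 `CCNC(=O)C1=Cc2ccc(OC)cc2OC1c1cc(OC)c(OC)c(OC)c1` gives in this assay only a limit, > 50000 nM. The measured steps on the amide position run a 1.4-fold lower number from compound 1 to compound 3 (0.15 log units; within the scatter) and an at least 2.0-fold higher number from compound 1 to compound 2 (0.30 log units; that floor lies within the scatter), while the clearest one is an at least 2.8-fold lower number from compound 2 to compound 3 (0.45 log units; beyond the scatter).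

Compound 4 `COc1ccc2c(c1)OC(c1cc(OC)c(OC)c(OC)c1)C(C(=O)N(C)OC)=C2` carries the change (methoxy(methyl)amino in place of anilino on a carbonyl carbon). The step that bears on it most is the move from compound 2 to compound 3, where the phenyl on the amide-type nitrogen went with a modest drop in the number; compound 4 gives that phenyl up again and has no ring at this position. A return toward higher numbers is therefore expected, roughly of the size seen between compound 2 and compound 3, so compound 4 is estimated at 40000 nM in this assay, within 15000 nM to 100000 nM, meaning an expected step of a 2.3-fold higher number from compound 3 to compound 4 (0.36 log units; beyond the scatter).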

Compound 4, half-maximal inhibitory concentration: 11700 nM
Estimate against measurement, compound 4: 3.4-fold (0.53 log units) above; the measured number lies below the stated range.
By their numbers in this assay, from the lowest: compounds 4, 3 and 1 (each within the scatter of the next, the first and the last beyond it). At a limit, above all of these: compound 2.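

Notes on the carbonyl substituent: in this assay the aromatic ring of the anilino group can be given up without a readable loss, as methoxy(methyl)amino in place of anilino gives a 1.5-fold lower number from compound 3 to compound 4 (0.17 log units; within the scatter) on this position. Methoxy(methyl)amino in place of ethoxy gives a 2.1-fold lower number from compound 1 to compound 4 (0.33 log units; beyond the scatter) and so shows that a lower number here does not depend on a ring on the amide-type nitrogen. Groups without a ring do not all behave alike, since methoxy(methyl)amino in place of ethylamino gives an at least 4.2-fold lower number from compound 2 to compound 4 (0.63 log units; beyond the scatter) as a floor only, and the reading for compound 2 is not a number: the limit of > 50000 nM in this assay, at which 1 of the 4 values shown sits.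

Going by these compounds, whether a morpholine amide or a carboxylic acid on this carbonyl carbon would take the number lower remains open. Also open, on these data alone, is whether a fluorine on the phenyl of the anilino group would separate from the unsubstituted ring.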